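Hexyl for hydroxy(phenyl)methyl on a nucleoside alkyne

The source may report more compounds than this note shows. Statements on the series, on what has been measured and on what is new or still open speak of the compounds shown alone.

Compound 1 `CCC#Cc1c[nH]c(=O)[nH]c1=O`: 263000 nM
Compound 2 `O=c1[nH]c(=O)n([C@@H]2O[C@H](CO)[C@@H](O)[C@H]2O)cc1C#CC(O)c1ccccc1`: 65400 nM
Compound 3 `O=c1[nH]cc(C#CC(O)c2ccccc2)c(=O)[nH]1`: 242000 nM

In an ADME assay on Vero cells (Chlorocebus sabaeus) for cytotoxicity, read by MTT assay (on this read-out lower numbers stand for higher toxicity in this test and higher numbers for lower toxicity in this test), compound 2 gives the lowest of the three numbers, with compound 3 nearest and compound 1 furthest. Removing the sugar gave a 3.7-fold higher number from compound 2 to compound 3 (0.57 log units; beyond the scatter). Compound 1 and compound 3 carry different groups on the triple-bonded carbon, yet their two values are similar. Compound 4 `CCCCCCC#Cc1cn([C@@H]2O[C@H](CO)[C@@H](O)[C@H]2O)c(=O)[nH]c1=O` keeps the sugar of compound 2 and differs by hexyl in place of hydroxy(phenyl)methyl on a triple-bonded carbon. Going by the values given here, no measured step matches this change; the only hint, from compound 1 and compound 3, points to no step beyond the scatter. Compound 4 is therefore expected at 90000 nM (range 40000 nM to 220000 nM), an estimated 1.4-fold higher number from compound 2 to compound 4 (0.14 log units; within the scatter).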

Compound 4, half-maximal cytotoxic concentration: 111000 nM
Beside the measured number, compound 4's estimate is 1.2-fold (0.09 log units) below it; low and high end bracket the measured number.
By their numbers in this assay, from the lowest: compounds 2 and 4 (each within the scatter of the next); then compounds 3 and 1 (each within the scatter of the next).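

Putting hexyl in place of hydroxy(phenyl)methyl on this triple-bonded carbon, with the sugar kept, gives a 1.7-fold higher number from compound 2 to compound 4 (0.23 log units; within the scatter) in this assay. In this one pair, the number stays within the scatter even though the six-membered aromatic ring and the hydroxy group both leave. Nothing available explains why these two groups read alike. From the compounds shown here alone, whether an amine, a carboxylic acid or a longer chain on this carbon would also stay this close to compound 2 remains open. Also open, going by these compounds, is how hexyl reads without the sugar, the form of compound 1 and compound 3.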